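The source may report more compounds than this note shows. Statements on the series, on what has been measured and on what is new or still open speak of the compounds shown alone.

Measured so far:
compound 1, `COc1ccc(/C=C2\SC(=O)N(CCNC(=O)Nc3c(C)n(C)n(-c4ccccc4)c3=O)C2=O)cc1`, 34500 nM
compound 2, `Cc1c(NC(=O)NCCN2C(=O)S/C(=C\c3ccc([N+](=O)[O-])cc3)C2=O)c(=O)n(-c2ccccc2)n1C`, 76400 nM
compound 3, `COc1ccc(/C=C2\SC(=O)N(CC(=O)Nc3c(C)n(C)n(-c4ccccc4)c3=O)C2=O)cc1`, 52900 nM

All three were run in a toxicity assay on WI-38 cells (Homo sapiens) for inhibition, read by MTT assay, with a stated time of 48 h; on this read-out lower numbers stand for stronger inhibition and higher numbers for weaker inhibition. Compound 1 and compound 2 share one core and differ in a single place, (nitro in place of methoxy on an aromatic carbon). That change gave a 2.2-fold higher number from compound 1 to compound 2 (0.35 log units; beyond the scatter).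

Compound 3 has a different core from compound 1; the difference between the two cores is not broken down here. In this assay compound 3 gives 52900 nM, which sits within the scatter of both compound 1 and compound 2, so no order among the three can be read from these numbers alone.

Compound 4, `Cc1c(NC(=O)CN2C(=O)S/C(=C\c3ccc([N+](=O)[O-])cc3)C2=O)c(=O)n(-c2ccccc2)n1C`, has not yet been measured. It stands to compound 3 as compound 2 stands to compound 1: the change is nitro in place of methoxy on an aromatic carbon, and its place line reads the same as for the earlier pair, so this is the same change on the other core. For the measured compounds named here, only one measured instance of it exists, so the expected step rests on compound 1 and compound 2 alone, because a 2.2-fold higher number from compound 1 to compound 2 (0.35 log units; beyond the scatter) is the only guide to its size. A step of about the same size is expected from compound 3 to compound 4, namely a 2.0-fold higher number from compound 3 to compound 4 (0.30 log units; within the scatter). On that basis compound 4 is estimated at 105000 nM in this assay, with a plausible range from 50000 nM to 250000 nM.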

Compound 4, half-maximal inhibitory concentration: 43800 nM
The estimate for compound 4 lay 2.4-fold (0.38 log units) above the measured number, outside the stated range (below it).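

In this assay, the change from 4-methoxyphenyl to 4-nitrophenyl on the core of compound 3 gives a 1.2-fold lower number from compound 3 to compound 4 (0.08 log units; within the scatter), and the step seen on the core of compound 1 does not carry over to this second core: the same change on two cores in this assay, a 2.2-fold higher number (0.35 log units; beyond the scatter) from compound 1 to compound 2 and a 1.2-fold lower number (0.08 log units; within the scatter) from compound 3 to compound 4, 2.7-fold (0.43 log units) apart, beyond the scatter of two such steps

The size of this change on one core is therefore a poor guide to its size on the other, and in this series it cannot be treated as a fixed increment to add to any core. This does not show that the change acts in the opposite direction on the second core, since its step there lies within the scatter, and with a single pair per core it does not show which feature of the cores separates the two results or whether the gap extends to other groups.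

The compounds shown leave open how an amine or a carboxylic acid on the same aromatic carbon would behave on each core, and so whether the gap is particular to the methoxy and nitro pair. For the compounds shown here, they also leave open whether a longer chain in place of the one in compound 3 would bring the step back towards that seen on the core of compound 1.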